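The source may report more compounds than this note shows. Statements on the series, on what has been measured and on what is new or still open speak of the compounds shown alone.

Series notes. Two compounds carry numbers in an assay on CHO cells for antagonist activity at transient receptor potential cation channel subfamily V member 1 (Homo sapiens), read by FLIPR; a higher number here means a weaker inhibitor, a lower number a stronger inhibitor. Compound 1 `CC(C(=O)NCc1ccc(C(F)(F)F)nc1-c1ccc(N(C)C)cc1)c1ccc(NS(C)(=O)=O)c(F)c1` gives in this assay 3.2 nM. Compound 2 `CC(C(=O)NCc1ccc(C(F)(F)F)nc1-c1ccc(Cl)c(Cl)c1)c1ccc(NS(C)(=O)=O)c(F)c1` gives in this assay 0.9 nM. Among the measured compounds shown here, the one measured step, a 3.6-fold lower number from compound 1 to compound 2 (0.55 log units; beyond the scatter), leaves compound 2 with the lowest of the two numbers; its nearest neighbour is compound 1, which stands beyond the scatter from it.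

Compound 3 `CC(C(=O)NCc1ccc(C(F)(F)F)nc1-c1ccc2c(c1)OCCO2)c1ccc(NS(C)(=O)=O)c(F)c1` is not yet measured. It differs from compound 2 in one place: 2,3-dihydro-1,4-benzodioxin-6-yl in place of 3,4-dichlorophenyl on an aromatic carbon. For the measured compounds named here, no measured step involves the 2,3-dihydro-1,4-benzodioxin-6-yl group, so the only step that bears on the change is the single one at this position, a 3.6-fold lower number from compound 1 to compound 2 (0.55 log units; beyond the scatter), in which the entering 3,4-dichlorophenyl group went with the lower number. Replacing that group once more takes away what accompanied the lower number, so the expectation for compound 3 is a number somewhat higher than that of compound 2, near or just beyond the scatter, with nothing to support a number below compound 2. The expected step is a 2.8-fold higher number from compound 2 to compound 3 (0.44 log units; beyond the scatter). For compound 3 the estimate in this assay is 2.5 nM, with a range from 0.8 nM to 8 nM.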

Compound 3, inhibition constant: 5 nM
Compound 3: the middle estimate sits 2.0-fold (0.30 log units) below what was measured; the measured number falls inside the stated range.
By their numbers in this assay, from the lowest: compound 2; then compounds 1 and 3 (each within the scatter of the next).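

In this assay, a second replacement at this position, on an aromatic carbon next to the ring nitrogen, does not keep the low number of compound 2: the 2,3-dihydro-1,4-benzodioxin-6-yl group in place of 3,4-dichlorophenyl gives a 5.6-fold higher number from compound 2 to compound 3 (0.74 log units; beyond the scatter). Against the 4-(dimethylamino)phenyl group the same entering group gives a 1.6-fold higher number from compound 1 to compound 3 (0.19 log units; within the scatter), so two quite different groups stand level here and, among these three compounds, only the 3,4-dichlorophenyl group of compound 2 stands apart. Nothing measured alongside these numbers bears on why that group stands apart.

On these data alone, whether the low number of compound 2 goes with both chlorine atoms or with only one remains open, and a 4-chlorophenyl, a 3-chlorophenyl or a plain phenyl group at this position would separate those cases. Also open, as far as these compounds go, is whether the same ranking of these groups would hold with a tert-butyl group in place of the trifluoromethyl group on the shared core.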